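A few compounds are considered here, and "the series" means these few. Any claim that something is new, unique, unknown or untested is made for them only; others in the source may bear on it.

Measured in a functional assay on KBVIN cells (Homo sapiens) for antiproliferative activity, read by sulforhodamine B assay, with a stated time of 48 h; a higher number here means a weaker inhibitor of growth, a lower number a stronger inhibitor of growth:
Compound 1 `COc1ccc(Nc2nc(NC3CCCC3)c3ccccc3n2)cc1`: 12600 nM
Compound 2 `COc1ccc(Nc2nc(NCCCO)c3ccccc3n2)cc1`: 17100 nM
Compound 3 `COc1ccc(N(C)c2nc(NC3CCCC3)c3ccccc3n2)cc1`: 10100 nM

Compound 1 does not separate from either of the other two compounds in this assay: the measured steps are a 1.4-fold higher number from compound 1 to compound 2 (0.13 log units; within the scatter) and a 1.2-fold lower number from compound 1 to compound 3 (0.10 log units; within the scatter), and both lie within the scatter. Compound 4 `Nc1ccc(Nc2nc(NC3CCCC3)c3ccccc3n2)cc1` keeps the rest of compound 1 and carries amino in place of methoxy on an aromatic carbon, para to a large group: amino in place of methoxy on an aromatic carbon. Going by the values given here, no measured step touches this position, since all three measured compounds retain the methoxy. The two steps available, 3-hydroxypropyl in place of cyclopentyl and methyl in place of hydrogen, bear on it only indirectly, showing that changes elsewhere on the core of compound 1 left the number within the scatter. The data therefore give no direction for this change, and no shift beyond the scatter is expected. The expected step is a 1.1-fold higher number from compound 1 to compound 4 (0.05 log units; within the scatter). The estimate for compound 4 is 14000 nM, with an expected range from 6000 nM to 35000 nM.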

Compound 4, concentration for 50% growth inhibition: 21700 nM
Compound 4: middle estimate off by 1.6-fold (0.19 log units), on the low side, and the stated range covers the measured number.
By their numbers in this assay, from the lowest: compounds 3, 1, 2 and 4 (each within the scatter of the next, the first and the last beyond it).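

Compound 4 is the first change shown on the 4-methoxyphenyl group of compound 1, a part that the earlier compounds all kept unchanged. In this assay the exchange of methoxy for amino gives a 1.7-fold higher number from compound 1 to compound 4 (0.24 log units; within the scatter) and so does not separate the two compounds, even though it swaps a group with no hydrogen-bond donor for one with a hydrogen-bond donor on the same aromatic carbon. Nothing available explains this result.

Going by these compounds, it remains open whether a hydroxyl, a dimethylamino group, a chlorine or a carboxylic acid on this carbon would move the number beyond the scatter. On these data alone, it is also open whether amino would behave the same way with the cyclopentyl replaced by 3-hydroxypropyl, or with a methyl on the linking nitrogen.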